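A Second Chloro Group on Compound 2

The source may report more compounds than this note shows. Statements on the series, on what has been measured and on what is new or still open speak of the compounds shown alone.

Measured compounds:
compound 1, `Clc1ccc(-c2csc(N/N=C/c3ccc(-n4ccnc4)cc3)n2)c(Cl)c1`, 28.8%
compound 2, `Clc1ccc(-c2csc(N/N=C/c3ccc(-n4cncn4)cc3)n2)cc1`, 28.4%

In an ADME assay on THP-1 cells (Homo sapiens) for cytotoxicity, read by MTT assay, tested at 50 ug/mL (on this read-out lower numbers stand for less inhibition and higher numbers for more inhibition at the one concentration tested (going by the name of the read-out)), compound 2 stands lowest of the two numbers, though compound 1 lies within the scatter of it, so the two show no difference. Compound 3, `Clc1ccc(-c2csc(N/N=C/c3ccc(-n4cncn4)cc3)n2)c(Cl)c1`, is not yet measured and differs from compound 2 by one change: chloro in place of hydrogen on an aromatic carbon. Among the measured compounds shown here, no measured pair shows this change alone, so the expected step of a number 1.6 percentage points higher from compound 2 to compound 3 (within the scatter) is none beyond the scatter, in either direction. Compound 3 is thus expected to give 30%, with a range from 18% to 42%.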

Compound 3, a percentage reported as inhibition, at one concentration (the size of the read-out at that concentration, not a potency): 8.9%
The estimate for compound 3 lay 21.1 percentage points above the measured number; the whole stated range lies above it.
By their numbers in this assay, from the lowest: compound 3; then compounds 2 and 1 (each within the scatter of the next).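

In this assay, the change from 4-chlorophenyl to 2,4-dichlorophenyl gives a number 19.5 percentage points lower from compound 2 to compound 3 (beyond the scatter), so a chloro group ortho to a large group is not a neutral addition when the triazolyl group is present. With the dichlorophenyl group kept, 1H-1,2,4-triazol-1-yl in place of 1H-imidazol-1-yl gives a number 19.9 percentage points lower from compound 1 to compound 3 (beyond the scatter), a step that the earlier pair, differing in two places, could not show. Nothing measured here explains either step. As far as these compounds go, it remains open whether a fluoro or methoxy group at this position would give a similar step, and whether the second chloro group has the same effect alongside the imidazolyl group.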